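Phenyl to cyclohexyl at the chain end of compound 2

A few compounds are considered here, and "the series" means these few. Any claim that something is new, unique, unknown or untested is made for them only; others in the source may bear on it.

Working notes on a short amide series read in a functional assay on PANC-1 cells (Homo sapiens) for cytotoxicity, read by WST assay, with a stated time of 24 h; a lower number here means a stronger inhibitor, a higher number a weaker inhibitor. Compound 1 `O=C(/C=C/CCCCCCc1ccccc1)N1CCCC1` is the unsaturated pyrrolidine-free comparator only in the sense of its own structure; in this assay compound 1 gives > 100000 nM, a limit of the assay and not a number. Compound 3 `S=C(CCCCCCCCc1ccccc1)N1CCCCC1` is the thioamide counterpart; in this assay compound 3 gives > 100000 nM, again a limit rather than a number. Compound 2 `O=C(CCCCCCCCc1ccccc1)N1CCCCC1` is the parent for the step followed here; in this assay compound 2 gives > 100000 nM, which is a limit of the assay and not a measured number. Compound 2 therefore stands exactly where everything measured so far stands, at the limit of > 100000 nM in this assay, at which 3 of the 3 values shown sit.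

The new compound is compound 4 `O=C(CCCCCCCCC1CCCCC1)N1CCCCC1`. Against compound 2 the difference is cyclohexyl in place of phenyl on a saturated chain carbon, eight bonds along the chain from a carbonyl carbon. Within the data shown here, no step between two measured compounds exists in this set, so the size of the change must be guessed. Among the measured compounds shown here, because the only evidence is the limit of > 100000 nM in this assay, at which 3 of the 3 values shown sit, the step that the limit leaves unreadable from compound 2 to compound 4 in this assay is expected to be none beyond the scatter, and most probably to remain a limit. Compound 4 is accordingly expected to give about 150000 nM, with a range from 50000 nM to 500000 nM.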

Compound 4, half-maximal inhibitory concentration: > 100000 nM
Compound 4 ended at the assay's limit (the forecaster's own chance of this, stated with the estimate: 85%); the middle value is on the limit's open side.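

In this assay compound 2 and compound 4 both stand at the limit of the assay, and no step can be read between them. The compounds shown leave open how phenyl and cyclohexyl at the chain end compare, and what any of these amides would give as a measured number rather than a limit.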